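Removing a chloro group from the benzoyl ring of a quinazoline thiosemicarbazide

A few compounds are considered here, and "the series" means these few. Any claim that something is new, unique, unknown or untested is made for them only; others in the source may bear on it.

Of the compounds shown here, three have been measured in a functional assay on KB cells (Homo sapiens) for cytotoxicity, read by MTT assay, with a stated time of 72 h; on this read-out lower numbers stand for stronger inhibition and higher numbers for weaker inhibition. Compound 1, `COc1cc2ncnc(NNC(=S)NC(=O)c3ccc(C(F)(F)F)cc3)c2cc1OC`, gives 8840 nM. Compound 2, `COc1cc2ncnc(NNC(=S)NC(=O)c3ccccc3C)c2cc1OC`, gives 11400 nM. Compound 3, `O=C(NC(=S)NNc1ncnc2ccccc12)c1cccc(Cl)c1`, gives 4740 nM, a number that differs from compound 1 only within the usual scatter, while compound 2 stands beyond the scatter above it.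

The next compound, compound 4, is `O=C(NC(=S)NNc1ncnc2ccccc12)c1ccccc1`. It differs from compound 3 by hydrogen in place of chloro on an aromatic carbon, so the benzoyl ring carries no substituent at all.

Going by the values given here, only one measured step touches the same part of the molecule, the swap of the aryl group on the carbonyl carbon in a 1.3-fold higher number from compound 1 to compound 2 (0.11 log units; within the scatter). That change, larger in size than the loss of a single chloro group, stayed within the scatter, and compounds 1 and 2 share a core that compounds 3 and 4 do not, so it bears on the present step only loosely. With nothing in the data showing a substituent on this ring to matter, no movement beyond the scatter is expected in this assay , and the step is estimated as a 1.3-fold higher number from compound 3 to compound 4 (0.10 log units; within the scatter).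

Compound 4 is therefore expected to give about 6000 nM, within a range of 2500 nM to 15000 nM.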

Compound 4, half-maximal inhibitory concentration: 2330 nM
Beside the measured number, compound 4's estimate is 2.6-fold (0.41 log units) above it; measured number outside the range, below it.
By their numbers in this assay, from the lowest: compound 4; then compounds 3, 1 and 2 (each within the scatter of the next, the first and the last beyond it).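

In this assay, going by these compounds alone, going from 3-chlorophenyl to phenyl on the carbonyl carbon gives a 2.0-fold lower number from compound 3 to compound 4 (0.31 log units; beyond the scatter), the first step on this aryl group to lie beyond the scatter. This shows that one substituent on this ring, a single chlorine atom on an aromatic carbon, can be enough to move the number, and that in this pair the ring with no substituent carries the lower number, so the chloro group is not needed for activity here. No measurement shown explains the shift, so the pair records only the size and direction of the change.

Going by these compounds, this is a single pair on a single core, so it remains open whether removing a chloro group would shift the number in the same direction on the core of compound 1. On these data alone, it also remains open how other groups at this same place on the ring would compare with hydrogen and chloro, whether a fluoro or bromo group, a methoxy group, an amine or a carboxylic acid.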